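Cyclopropyl for Methyl on a Second Core

The source may hold more compounds than are shown below. What is called first, only, known or untested is meant among the compounds shown, and "the series" means these compounds.

Measured so far:
compound 1, `CC(=O)Nc1n[nH]c2cc(-c3cn([C@@H]4CN[C@H](C(=O)Nc5ccc(Br)cc5)C4)nn3)ccc12`, 3830 nM
compound 2, `O=C(Nc1n[nH]c2cc(-c3cn([C@@H]4CN[C@H](C(=O)Nc5ccc(Br)cc5)C4)nn3)ccc12)C1CC1`, 8080 nM
compound 3, `CC(=O)Nc1nc2ccc(-c3cn([C@@H]4CN[C@H](C(=O)Nc5ccc(Cl)c(C(F)(F)F)c5)C4)nn3)nc2s1`, 10000 nM

All three were tested in a functional assay on K562 cells (Homo sapiens) for inhibition, read by MTT assay, with a stated time of 48 h; a lower number here means a stronger inhibitor, a higher number a weaker inhibitor. Compound 1 and compound 2 share one core and differ only by cyclopropyl in place of methyl on a carbonyl carbon; that change gave a 2.1-fold higher number from compound 1 to compound 2 (0.32 log units; beyond the scatter). Compound 3 sits on a different core; how its core differs from that of compound 1 is not broken down here. Compound 3 has the highest number of the three, with compound 2 near it and compound 1 further off.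

Compound 4, `O=C(Nc1nc2ccc(-c3cn([C@@H]4CN[C@H](C(=O)Nc5ccc(Cl)c(C(F)(F)F)c5)C4)nn3)nc2s1)C1CC1`, is not yet measured. It differs from compound 3 by cyclopropyl in place of methyl on a carbonyl carbon, the same change as between compound 1 and compound 2, at the same kind of place. The step from compound 3 to compound 4 is expected to be a 1.8-fold higher number from compound 3 to compound 4 (0.26 log units; within the scatter), because the same change gave a 2.1-fold higher number from compound 1 to compound 2 (0.32 log units; beyond the scatter). Compound 4 is therefore expected to give about 18000 nM, within a range from 8000 nM to 40000 nM.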

Compound 4, half-maximal inhibitory concentration: 16200 nM
Compound 4: middle estimate off by 1.1-fold (0.05 log units), on the high side, within the range that was stated.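

In this assay, putting cyclopropyl in place of methyl on the carbonyl carbon of compound 3 gives a 1.6-fold higher number from compound 3 to compound 4 (0.21 log units; within the scatter), so this step alone cannot be told apart from the ordinary spread of repeated measurements. Set beside the earlier step, it shows that the change gave a similar result on both cores, with no detectable gap between them: the same change on two cores in this assay, a 2.1-fold higher number (0.32 log units; beyond the scatter) from compound 1 to compound 2 and a 1.6-fold higher number (0.21 log units; within the scatter) from compound 3 to compound 4, 1.3-fold (0.11 log units) apart, within the scatter of two such steps. Going by these compounds alone, this is some support for carrying the change from one core to the other, but it rests on only two pairs of compounds, and it does not show that the same step would appear on any further core or explain why the numbers move as they do.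

The compounds shown leave open what other groups on the same carbonyl carbon would do, such as a longer chain like propyl, a branched isopropyl or a phenyl ring. They also leave open how either core would behave with a free amine in place of the acetamido group.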